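The source may hold more compounds than are shown below. What is called first, only, known or untested is meant among the compounds shown, and "the series" means these compounds.

Three compounds have been measured in a functional assay on Hep 3B2 cells (Homo sapiens) for antiproliferative activity, read by MTT assay, with a stated time of 72 h; on this read-out higher numbers stand for weaker inhibition and lower numbers for stronger inhibition:

Compound 1, `COc1cccc(CNCc2c(C(=O)O)n(Cc3ccc(C)cc3)c3cc(C)ccc23)c1`: 6330 nM
Compound 2, `COc1cccc(CNCc2c(C(=O)O)n(Cc3ccccc3)c3cc(C(C)C)ccc23)c1`: 4110 nM
Compound 3, `COc1ccc(Cn2c(C(=O)O)c(CNCc3cccc(O)c3)c3ccc(C(C)C)cc32)cc1`: 6600 nM

Compound 2 gives the lowest of the three numbers, but its distance to compound 1 and to compound 3 is within the usual scatter of this assay, so none of the three can be set apart from the others on these values. Compound 1 and compound 2 differ in more than one place, and so do compound 2 and compound 3; their values show only that all three lie close together.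

Compound 4, `COc1cccc(CNCc2c(C(=O)O)n(Cc3ccc(C)cc3)c3cc(C(C)C)ccc23)c1`, is the next compound. It is related to compound 2 by one change: methyl in place of hydrogen on an aromatic carbon. Going by the values given here, no measured pair in this set shows this change on its own, so there is no direct precedent for its effect. With the three values sitting so close together, the step from compound 2 to compound 4 is expected to stay within the scatter, in either direction: a 1.0-fold higher number from compound 2 to compound 4 (0.01 log units; within the scatter). Compound 4 is therefore estimated to give about 4200 nM, with a range from 2000 nM to 8500 nM.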

Compound 4, half-maximal inhibitory concentration: 4070 nM
The estimate for compound 4 lay 1.0-fold (0.01 log units) above the measured number; the range from low to high includes it.
By their numbers in this assay, from the lowest: compounds 4, 2, 1 and 3 (each within the scatter of the next).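

Going by these compounds alone, these are the first two single-change pairs in this set, and neither separates its compounds in this assay. Going from phenyl to 4-methylphenyl gives a 1.0-fold lower number from compound 2 to compound 4 (0.00 log units; within the scatter), so on these numbers compound 2 and compound 4 cannot be told apart, and methyl in place of hydrogen on that aromatic carbon has no measurable effect here. With isopropyl in place of methyl on an aromatic carbon of the core, the step is a 1.6-fold lower number from compound 1 to compound 4 (0.19 log units; within the scatter), so that pair also cannot be told apart, and no evidence available here bears on these results.

The compounds shown leave open whether a chlorine atom, an amine or a longer chain on the benzyl ring would give a step beyond the scatter. They also leave open whether a longer chain in place of the isopropyl would do so.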